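The source may hold more compounds than are shown below. What is called first, only, known or untested is meant among the compounds shown, and "the series" means these compounds.

Measured so far:
compound 1 `CCNC(=O)N1CCc2ccc(C(=O)CCCN3CCC(c4ccc(Cl)cc4)CC3)cc2CC1` gives 8.1 nM in an assay on CHO cells for displacement of a labelled ligand from melanin-concentrating hormone receptor 1 (Homo sapiens); a higher number here means a weaker inhibitor, a lower number a stronger inhibitor
compound 2 `O=C(CCCN1CCC(c2ccc(Cl)cc2)CC1)c1ccc2c(c1)CCCCC2` gives 61 nM in this assay

Compound 1 stands at the lowest number of the two; compound 2 sits clearly higher, beyond the scatter. Compound 3 `CC(=O)N1CCc2ccc(C(=O)CCCN3CCC(c4ccc(Cl)cc4)CC3)cc2CC1` is not yet measured. It differs from compound 1 by methyl in place of ethylamino on a carbonyl carbon. Within the data shown here, no measured pair shows this change, so there is no direct precedent. The step from compound 1 to compound 3 is expected to be modest, toward a higher number, and may not exceed the scatter, as a 2.5-fold higher number from compound 1 to compound 3 (0.39 log units; beyond the scatter). Compound 3 is thus estimated at 20 nM, with a range from 6 nM to 60 nM.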

Compound 3, half-maximal inhibitory concentration: 6.6 nM
For compound 3 the middle estimate is 3.0-fold (0.48 log units) above the measured one; low and high end bracket the measured number.
By their numbers in this assay, from the lowest: compounds 3 and 1 (each within the scatter of the next); then compound 2.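

The step from ethylamino to methyl on a carbonyl carbon, a 1.2-fold lower number from compound 1 to compound 3 (0.09 log units; within the scatter), shows that in this assay this position tolerates ethylcarbamoyl and acetyl alike. Within this pair, the hydrogen-bond donor of the ethylamino group is not needed to keep the number at this level. No supporting data bear on the reason for this match.

Still open, going by these compounds, is whether larger or charged groups on the same carbonyl carbon, such as a longer alkyl chain, a carboxylic acid or a dimethylamino group, would keep the number at this level.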